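The compounds below may be only part of what the source reports. "The series", "measured", "known", "first", "only" and "open" are said of these compounds alone.

Measured in a functional assay on the whole organism with Rattus norvegicus as the target, in the maximal electroshock model; on this read-out higher numbers stand for an effect only at larger amounts of compound and lower numbers for an effect already at smaller amounts:
Compound 1 `Fc1ccccc1Cn1ccc2c(NC3CC3)ncnc21`: > 50 mg/kg, a limit
Compound 2 `CNc1ncnc2c1cnn2Cc1ccccc1`: 7 mg/kg

Among the compounds with values here, compound 2 holds the only actual number in this assay, since the result for compound 1 is a limit. Compound 3 `Nc1ncnc2c1cnn2Cc1ccccc1` has hydrogen in place of methyl on a nitrogen on an aromatic ring, which turns methylamino to amino. Within the data shown here, no measured pair shows this change, so the expectation is tentative. A modest move toward larger doses is expected in this assay, and the estimated step is a 2.1-fold higher number from compound 2 to compound 3 (0.33 log units; beyond the scatter). For compound 3 the estimated value is 15 mg/kg, with an expected range of 5 mg/kg to 50 mg/kg.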

Compound 3, dose for half-maximal effect: > 25 mg/kg
Compound 3: no number, only a limit; the forecaster's own chance of this, stated with the estimate: 25%; at least 1.6-fold (0.22 log units) between middle value and limit.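

Going from methylamino to amino gives the first one-place step at this nitrogen in this assay, and it is an at least 3.5-fold higher number from compound 2 to compound 3 (0.55 log units; beyond the scatter). Compound 1 differs from compound 2 in more than one place, so its result could not show this. Compound 3 has a limit rather than a number, so the step gives only the smallest size the change can have: the limit of > 25 mg/kg in this assay, at which 1 of the 3 values shown sits.

The compounds shown leave open whether an ethyl group or a longer chain on this nitrogen would keep the effect at smaller doses.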